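This account rests on a few compounds, and the source may have more. Where it says the series, first, only, none or still open, it means among the compounds named here.

Among the measured compounds shown here, compound 2 `CCCCCCOC(=O)/C=C/c1ccc(NC(=O)C2(NC(=O)c3ccc4c(C5CCCC5)c(-c5ncc(Cl)cn5)n(C)c4c3)CCC2)cc1OCC` holds the higher of the two numbers so far: in an ADME assay (liver) for pharmacokinetics, with Liver microsome (Homo sapiens) as the target, using microsomes (on this read-out higher numbers stand for a longer-lived compound and lower numbers for a shorter-lived compound), compound 2 gives 17.9 h, while compound 1 `CCOc1cc(NC(=O)C2(NC(=O)c3ccc4c(C5CCCC5)c(-c5ncc(Cl)cn5)n(C)c4c3)CCC2)ccc1/C=C/C(=O)OCOP(=O)(O)O` gives 0.167 h. Compound 3 `CCOc1cc(NC(=O)C2(NC(=O)c3ccc4c(C5CCCC5)c(-c5ncc(Cl)cn5)n(C)c4c3)CCC2)ccc1/C=C/C(=O)OCC(N)=O` carries carbamoyl in place of pentyl on a saturated chain carbon bound to an oxygen next to a carbonyl group. For the measured compounds named here, only one measured step speaks to this kind of swap: a 110-fold higher number from compound 1 to compound 2 (2.03 log units; beyond the scatter), where a group with 4 oxygen and 1 phosphorus gave way to pentyl. A carbamoyl group sits between those two extremes, so a drop from compound 2 is expected, yet smaller than that step; the expected change is a 6.0-fold lower number from compound 2 to compound 3 (0.78 log units; beyond the scatter). Compound 3 is therefore estimated at 3 h, between 0.5 h and 15 h.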

Compound 3, half-life: 0.983 h
Compound 3: middle estimate off by 3.1-fold (0.48 log units), on the high side, within the range that was stated.
By their numbers in this assay, from the lowest: compound 1; then compound 3; then compound 2.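

Carbamoyl in place of pentyl gives an 18-fold lower number from compound 2 to compound 3 (1.26 log units; beyond the scatter) in half-life, so a large change at this place does not depend on a phosphorus-bearing group. Compared with that group, carbamoyl gives a 5.9-fold higher number from compound 1 to compound 3 (0.77 log units; beyond the scatter) and so sets a third, separate level among these esters. No measurement given here explains these differences. A shorter plain chain such as ethyl would help show how much of the drop follows chain length and how much follows the carbamoyl group itself. On these data alone, how a carboxylic acid or an amine at this place would behave remains open.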